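The compounds below may be only part of what the source reports. "The series", "measured", "known", "first", "only" and "open" are said of these compounds alone.

Working notes on the series. In a functional assay on B16 cells (Mus musculus) for antiproliferative activity, read by MTT assay, with a stated time of 24 h (on this read-out higher numbers stand for weaker inhibition and lower numbers for stronger inhibition), compound 1 (`COc1cc(OC)c(-c2coc3cc(OCc4ccccc4F)ccc3c2=O)cc1OC`) gives 1610 nM and compound 2 (`COc1cc(OC)c(-c2coc3cc(OCc4ccccc4C)ccc3c2=O)cc1OC`) gives 2150 nM while compound 3 (`COc1cc(OC)c(-c2coc3cc(OCc4cccc(F)c4)ccc3c2=O)cc1OC`) gives 2440 nM on the same scale. Compound 3 therefore sits level with the other two, and neither of its steps (a 1.5-fold higher number from compound 1 to compound 3 (0.18 log units; within the scatter); a 1.1-fold higher number from compound 2 to compound 3 (0.05 log units; within the scatter)) lies beyond the scatter.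

Compound 4 (`COc1cc(OC)c(-c2coc3cc(OCc4ccc(Cl)cc4)ccc3c2=O)cc1OC`) carries 4-chlorophenyl in place of 3-fluorophenyl on a saturated chain carbon bound to an oxygen on an aromatic ring.

The nearest evidence is the set of changes to the same aryl group. These are the two steps above and the methyl-for-fluoro step (a 1.3-fold higher number from compound 1 to compound 2 (0.13 log units; within the scatter)), and all three stay within the scatter. Within the data shown here, no measured compound carries 4-chlorophenyl, so the data do not show this group directly, and the three compounds cover only a narrow set of changes. No step beyond the scatter is expected in this assay.

The expected change is a 1.2-fold lower number from compound 3 to compound 4 (0.07 log units; within the scatter) and is not expected to exceed the scatter. The estimate for compound 4 is 2100 nM with an expected range from 1000 nM to 4500 nM in this series.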

Compound 4, half-maximal inhibitory concentration: 2400 nM
For compound 4 the middle estimate is 1.1-fold (0.06 log units) below the measured one; low and high end bracket the measured number.
By their numbers in this assay, from the lowest: compounds 1, 2, 4 and 3 (each within the scatter of the next).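

In this assay, among these compounds, the first aryl group with chlorine at this place, on a saturated chain carbon bound to an oxygen on an aromatic ring, stays within the scatter of all three earlier compounds: a 1.0-fold lower number from compound 3 to compound 4 (0.01 log units; within the scatter), a 1.1-fold higher number from compound 2 to compound 4 (0.05 log units; within the scatter) and a 1.5-fold higher number from compound 1 to compound 4 (0.17 log units; within the scatter). The four aryl groups, 2-fluorophenyl, 2-methylphenyl, 3-fluorophenyl and 4-chlorophenyl, therefore cannot be told apart in this assay, and the exchange of 3-fluorophenyl for 4-chlorophenyl leaves no readable change. Nothing at hand offers an explanation for this result.

On these data alone, it remains open whether a group of another kind at this place, such as an amine, a carboxylic acid or a longer chain, would give a step beyond the scatter. The compounds shown also leave open whether changes to the shared core would do so.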